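Thiosemicarbazone series: methoxy to hydroxy on the aryl ring

A few compounds are considered here, and "the series" means these few. Any claim that something is new, unique, unknown or untested is made for them only; others in the source may bear on it.

Compound 3 `COc1ccc(/C=N\NC(=S)NC(C)(C)CCC[C@](C)(O)[C@@H]2CC=C(C)CC2)cc1` gives 7660 nM in a functional assay on PCO3 cells (Homo sapiens) for cytotoxicity, read by sulforhodamine B assay (on this read-out higher numbers stand for weaker inhibition of growth and lower numbers for stronger inhibition of growth), the lowest number of the three, though its gap to compound 2 is within the scatter. Compound 2 `CC1=CC[C@@H]([C@@](C)(O)CCCC(C)(C)NC(=S)N/N=C\c2ccccc2)CC1` gives 8470 nM and compound 1 `CC1=CC[C@@H]([C@@](C)(O)CCCC(C)(C)NC(=S)NN)CC1` gives 26800 nM. The steps of a 3.2-fold lower number from compound 1 to compound 2 (0.50 log units; beyond the scatter) and a 3.5-fold lower number from compound 1 to compound 3 (0.54 log units; beyond the scatter) are modest, while a 1.1-fold lower number from compound 2 to compound 3 (0.04 log units; within the scatter) stays within the scatter. Compound 4 `CC1=CC[C@@H]([C@@](C)(O)CCCC(C)(C)NC(=S)N/N=C\c2ccc(O)cc2)CC1` differs from compound 3 by hydrogen in place of methyl on an oxygen on an aromatic ring, methoxy to hydroxy. Within the data shown here, the only measured step that touches this part of the structure is a 1.1-fold lower number from compound 2 to compound 3 (0.04 log units; within the scatter), which shows methoxy in place of hydrogen did not move this assay beyond the scatter, so no step beyond the scatter is expected here either. Compound 4 is therefore estimated at 7500 nM, range 3500 nM to 16000 nM, meaning a 1.0-fold lower number from compound 3 to compound 4 (0.01 log units; within the scatter).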

Compound 4, concentration for 50% growth inhibition: 6230 nM
Estimate against measurement, compound 4: 1.2-fold (0.08 log units) above; the range from low to high includes it.
By their numbers in this assay, from the lowest: compounds 4, 3 and 2 (each within the scatter of the next); then compound 1.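

In this assay, the hydroxy analogue gives a 1.2-fold lower number from compound 3 to compound 4 (0.09 log units; within the scatter) and a 1.4-fold lower number from compound 2 to compound 4 (0.13 log units; within the scatter) with both steps printed as within the scatter, so hydrogen, methoxy and hydroxy on the aromatic ring cannot be told apart here. The 4-hydroxyphenyl group in place of one nitrogen atom also keeps the modest gain, with a 4.3-fold lower number from compound 1 to compound 4 (0.63 log units; beyond the scatter) as the step beyond the scatter. Nothing available accounts for this flat response to the aryl substituent.

Still open, going by these compounds, is whether an amine, a carboxylic acid or a longer alkoxy chain at this place on the aromatic ring would move the number beyond the scatter.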